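Swapping the dimethoxyphenyl of compound 1 for cyclohexyl

The source may hold more compounds than are shown below. What is called first, only, known or untested is meant among the compounds shown, and "the series" means these compounds.

Compound 1 `COc1ccc(CNc2nc(=O)c3cc(C(F)(F)F)cc([N+](=O)[O-])c3o2)cc1OC`: 29.2 ug/mL
Compound 2 `COc1ccc(CN(C)c2nc(=O)c3cc(C(F)(F)F)cc([N+](=O)[O-])c3o2)cc1OC`: 9.46 ug/mL
Compound 3 `C[C@H]1COC2(CCN(c3nc(=O)c4cc(C(F)(F)F)cc([N+](=O)[O-])c4s3)CC2)O1`: > 64 ug/mL

Three compounds were tested in an ADME assay on Vero cells (Chlorocebus sabaeus) for cytotoxicity, read by MTT assay, with a stated time of 48 h; on this read-out lower numbers stand for stronger inhibition and higher numbers for weaker inhibition. Compound 1 holds the highest of the two numbers shown; its nearest neighbour is compound 2, with a 3.1-fold lower number from compound 1 to compound 2 (0.49 log units; beyond the scatter), a modest step. Compound 3 gives > 64 ug/mL, which is a limit of the assay rather than a number, as noted by the limit of > 64 ug/mL in this assay, at which 1 of the 3 values shown sits.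

Compound 4 `O=c1nc(NCC2CCCCC2)oc2c([N+](=O)[O-])cc(C(F)(F)F)cc12` differs from compound 1 by cyclohexyl in place of 3,4-dimethoxyphenyl on a saturated chain carbon bound to a nitrogen on an aromatic ring. Among the compounds with values here, no measured step changes this part of the molecule, so the one step known, between compound 1 and compound 2, does not bear on it. The expectation for compound 4 in this assay is therefore no step beyond the scatter, a 1.0-fold higher number from compound 1 to compound 4 (0.01 log units; within the scatter), giving an estimated 30 ug/mL, within 12 ug/mL to 64 ug/mL.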

Compound 4, half-maximal inhibitory concentration: 29.7 ug/mL
For compound 4 the middle estimate is 1.0-fold (0.00 log units) above the measured one; low and high end bracket the measured number.
By their numbers in this assay, from the lowest: compound 2; then compounds 1 and 4 (each within the scatter of the next). At a limit, above all of these: compound 3.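

Replacing 3,4-dimethoxyphenyl with cyclohexyl gives a 1.0-fold higher number from compound 1 to compound 4 (0.01 log units; within the scatter) in this assay. For this pair, at this place, neither the aromatic ring nor the two hydrogen-bond acceptors of the group that leaves are needed to keep the number where it is. Nothing shown here explains why the two groups read alike.

On these data alone, what an amine or a carboxylic acid would give on the same chain carbon stays open. Also open, as far as these compounds go, is whether methyl in place of hydrogen on the nitrogen would lower the number with cyclohexyl present, as it does from compound 1 to compound 2.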